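Rigidifying the amide amine in a benzyloxybenzamide series

The source may report more compounds than this note shows. Statements on the series, on what has been measured and on what is new or still open speak of the compounds shown alone.

Three compounds set the stage. Compound 1 `CCN(C(=O)c1ccccc1OCc1ccccc1)[C@@H]1CCC[C@H](NC(C)=O)C1` sits at a limit in an assay on HEK293 cells for inhibition of transient receptor potential cation channel subfamily M member 8 (Homo sapiens), read by FLIPR and calcium flux (a higher number here means a weaker inhibitor, a lower number a stronger inhibitor), reported as > 5000 nM. Compound 2 `CCN(C(=O)c1ccccc1OCc1ccccc1)[C@@H]1CC[C@@H](N)C1` gives 2600 nM in this assay. Within the data shown here, compound 3 `CN(C(=O)c1ccccc1OCc1ccccc1)[C@@H]1CCNC1` also sits at a limit, > 10000 nM, so for compound 3 only a range is known, and one further value shown is a limit as well; it stands at the weaker end of the numbers so far (the limit of > 10000 nM in this assay, at which 1 of the 3 values shown sits).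

Compound 4 `O=C(c1ccccc1OCc1ccccc1)N1C[C@H]2CNC[C@H]2C1` carries the change a group of 8 heavy atoms (6 carbon, 2 nitrogen; 2 five-membered non-aromatic rings with 1 hetero atom each) in place of a group of 7 heavy atoms (5 carbon, 2 nitrogen; one five-membered non-aromatic ring with 1 hetero atom), on a carbonyl carbon.

Among the measured compounds shown here, with no measured step to guide it, no shift beyond the scatter is expected in this assay, and the step from compound 3 to compound 4 is estimated as an at least 1.1-fold lower number from compound 3 to compound 4 (0.04 log units; that floor lies within the scatter). Compound 4 is expected to give about 9000 nM, most likely between 2500 nM and 30000 nM, quite possibly again as a limit.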

Compound 4, antagonist equilibrium constant: > 10000 nM
Compound 4: a limit, no number; the forecaster's own chance of this, stated with the estimate: 60%; middle value at least 1.1-fold (0.04 log units) away from the limit.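

Compound 3 and compound 4 both stand only as limits, so the step between them cannot be read: the limit of > 10000 nM in this assay, at which 2 of the 4 values shown sit.

The compounds shown leave open how much weaker than their shared limit either compound is in this assay.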